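This account rests on a few compounds, and the source may have more. Where it says the series, first, only, none or still open, it means among the compounds named here.

Measured in a functional assay on P388 cells (Mus musculus) for inhibition; a higher number here means a weaker inhibitor, a lower number a stronger inhibitor:
- compound 1 `O=C1CCCCC/C1=C\c1ccccc1`: > 50000 nM (a limit)
- compound 2 `O=C1CCCCC/C1=C\c1ccc(Br)cc1`: 16800 nM
- compound 3 `Cc1ccc(/C=C2\CCCCCC2=O)cc1`: > 50000 nM (a limit)

Compound 3 gives no exact number, only the limit > 50000 nM. It has company there: the limit of > 50000 nM in this assay, at which 2 of the 3 values shown sit. The next compound is compound 4 `CN(C)c1ccc(/C=C2\CCCCCC2=O)cc1`, which has dimethylamino in place of methyl on an aromatic carbon.

Going by the values given here, none of the three measured compounds carries dimethylamino, so no measured step tests this group directly. The nearest evidence comes from changes at the same place on the ring. Putting methyl in place of hydrogen gave a step that the two limits leave unreadable from compound 1 to compound 3. Putting bromo in place of hydrogen gave an at least 2.9-fold lower number from compound 1 to compound 2 (0.47 log units; beyond the scatter), and methyl in place of bromo gave an at least 2.9-fold higher number from compound 2 to compound 3 (0.47 log units; beyond the scatter). Among these three compounds, then, only the bromo compound yielded a number, and that is a modest gain at best.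

With so little to go on, compound 4 is expected to stay close to compound 3, quite possibly at the same limit, with no firm direction. The expected change is an at least 1.1-fold lower number from compound 3 to compound 4 (0.04 log units; that floor lies within the scatter). For compound 4 the estimated value is 45000 nM, with an expected range from 15000 nM to 120000 nM.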

Compound 4, half-maximal inhibitory concentration: 18800 nM
The estimate for compound 4 lay 2.4-fold (0.38 log units) above the measured number; measured number inside the range.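

Until now, the bromo compound was the only one to give a real number in this assay. Compound 4 shows that this is not unique to bromo: with dimethylamino at the same place on the ring, the result is an at least 2.6-fold lower number from compound 3 to compound 4 (0.42 log units; beyond the scatter), and measured against the unsubstituted ring it is an at least 2.6-fold lower number from compound 1 to compound 4 (0.42 log units; beyond the scatter). Bromo and dimethylamino cannot be told apart here, as the swap between them gives a 1.1-fold higher number from compound 2 to compound 4 (0.05 log units; within the scatter), while compound 1 and compound 3, with hydrogen and methyl at this place, still give no number, only a limit of the assay: the limit of > 50000 nM in this assay, at which 2 of the 4 values shown sit.

As far as these compounds go, whether a primary amine, a methoxy group or a carboxylic acid at this place would also give a number, and whether any group would go clearly beyond the level shared by bromo and dimethylamino, stays open. The true size of the gain over hydrogen or methyl is open too, as the two limits allow only a floor for it, and the four compounds cannot show what bromo and dimethylamino have in common that hydrogen and methyl lack.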